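This account rests on a few compounds, and the source may have more. Where it says the series, first, only, none or still open, it means among the compounds named here.

Measured so far in a functional assay on HEK293 cells for activation of melanin-concentrating hormone receptor 1 (Rattus norvegicus), read by inositol phosphate accumulation; on this read-out higher numbers stand for an effect only at larger amounts of compound and lower numbers for an effect already at smaller amounts:
compound 1 `O=C(CCc1ccc(C(F)(F)F)cc1)Nc1ccc2nc(N3CCC3)ccc2c1` gives 56 nM
compound 2 `CN(C)c1ccc2cc(NC(=O)CCc3ccc(C(F)(F)F)cc3)ccc2n1` gives 110 nM

Compound 2 stands within the scatter of compound 1: a 2.0-fold higher number from compound 1 to compound 2 (0.29 log units; within the scatter). Compound 3 `O=C(CCc1ccc(C(F)(F)F)cc1)Nc1ccc2nc(N3CC4CC3CO4)ccc2c1` is not yet measured; it differs from compound 2 by a group of 7 heavy atoms (5 carbon, 1 nitrogen, 1 oxygen; 2 five-membered non-aromatic rings with 1 hetero atom each) in place of a group of 3 heavy atoms (2 carbon, 1 nitrogen; no ring), on an aromatic carbon. Going by the values given here, the only measured step at this position, a 2.0-fold higher number from compound 1 to compound 2 (0.29 log units; within the scatter), exchanged one small amine for another and stayed within the scatter; the entering group of compound 3, with its two five-membered non-aromatic rings, again carries rings, as the azetidin-1-yl of compound 1 does. No step beyond the scatter is therefore expected in this assay. Compound 3 is estimated at 70 nM, range 25 nM to 200 nM, an expected step of a 1.6-fold lower number from compound 2 to compound 3 (0.20 log units; within the scatter).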

Compound 3, half-maximal effective concentration: 70 nM
For compound 3 middle estimate and measured number coincide at the digits printed; the range from low to high includes it.
By their numbers in this assay, from the lowest: compounds 1, 3 and 2 (each within the scatter of the next).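

In this assay the position next to the ring nitrogen also accepts a group of 7 heavy atoms with 2 five-membered non-aromatic rings, with no step beyond the scatter (a 1.6-fold lower number from compound 2 to compound 3 (0.20 log units; within the scatter); a 1.3-fold higher number from compound 1 to compound 3 (0.10 log units; within the scatter)). Across 3, 4 and 7 heavy atoms, and with a second hydrogen-bond acceptor in the entering group, these three compounds stay within the scatter of one another. No measurement on hand offers an explanation for this.

Still open, on these data alone, is whether any group here moves the number beyond the scatter, such as a primary amine, a piperazine or a carboxylic acid. The compounds shown also leave open how this position behaves with a longer chain on the amine nitrogen.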